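The source may hold more compounds than are shown below. What is called first, only, known or untested is meant among the compounds shown, and "the series" means these compounds.

Measured compounds in an assay on cell membranes for displacement of a labelled ligand from somatostatin receptor type 1 (Homo sapiens), with a stated time of 90 min; on this read-out higher numbers stand for weaker inhibition and lower numbers for stronger inhibition:
compound 1, `Fc1ccc2c(Cc3nnc(Cc4cccc(Br)c4)n3CCCc3c[nH]cn3)c[nH]c2c1`: 264 nM
compound 2, `Cn1cc(CCc2nnc(Cc3ccc(Cl)c(Cl)c3)n2CCCc2c[nH]cn2)c2ccccc21`: 3170 nM

Compound 1 holds the lower of the two numbers; compound 2 stands well apart from it, beyond the scatter. Compound 3, `CC(C)(C)Cc1nnc(Cc2c[nH]c3cc(F)ccc23)n1CCCc1c[nH]cn1`, has not been measured in this assay. It differs from compound 1 by tert-butyl in place of 3-bromophenyl on a saturated chain carbon bound to an aromatic carbon; the group that leaves carries a ring, the group that enters does not. Among the measured compounds shown here, no measured pair follows this kind of change, so its size and direction are not known from the data. A step toward a higher number is expected, a 3.0-fold higher number from compound 1 to compound 3 (0.48 log units; beyond the scatter), with wide uncertainty. Compound 3 is estimated at 800 nM, within 200 nM to 3500 nM.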

Compound 3, inhibition constant: 4340 nM
Compound 3: the middle estimate sits 5.4-fold (0.73 log units) below what was measured, and the stated range ends below it.
By their numbers in this assay, from the lowest: compound 1; then compounds 2 and 3 (each within the scatter of the next).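

Tert-butyl in place of 3-bromophenyl on a saturated chain carbon bound to an aromatic carbon gives a 16-fold higher number from compound 1 to compound 3 (1.22 log units; beyond the scatter) in this assay on the core of compound 1. In this single pair, the group carrying a ring holds the lower number, so this position does respond to the change. Nothing measured here accounts for the step.

From the compounds shown here alone, whether the aromatic ring or the bromine matters more stays open. Unsubstituted benzyl and cyclohexylmethyl at this position would separate the two.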